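A few compounds are considered here, and "the series" means these few. Any claim that something is new, unique, unknown or untested is made for them only; others in the source may bear on it.

Measured compounds in a functional assay on A2780 cells (Homo sapiens) for cytotoxicity, read by MTT assay, with a stated time of 72 h; on this read-out lower numbers stand for stronger inhibition and higher numbers for weaker inhibition:
- compound 1, `Nc1ccccc1NC(=O)CCCCCN(CC(=O)NC1CCCCC1)C(=O)c1ccccc1`, gives 181000 nM
- compound 2, `Cc1cc(C)cc(CNC(=O)CN(CCCCCC(=O)Nc2ccccc2N)C(=O)c2cc(C)cc(C)c2)c1`, gives 5100 nM
- compound 3, `Nc1ccccc1NC(=O)CCCCCN(CC(=O)NCc1ccccc1)C(=O)c1cccc2ccccc12`, gives 22800 nM

Compound 2 stands at the lowest number of the three in this assay. The nearest of the other two is compound 3, whose number is higher by a margin beyond the scatter; compound 1 is furthest, also beyond the scatter. Among the compounds with values here, the three compounds differ from one another in more than one place, so no single step between measured compounds is available.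

Compound 4, `Cc1ccc(CNC(=O)CN(CCCCCC(=O)Nc2ccccc2N)C(=O)c2cc(C)cc(C)c2)cc1`, has not yet been measured. It differs from compound 2 in one place only: 4-methylphenyl in place of 3,5-dimethylphenyl on a saturated chain carbon bound to an amide-type nitrogen. Within the data shown here, nothing among the measured compounds isolates this change, since compound 3 carries a benzyl group without methyl substitution and at the same time a different acyl group, so its value against compound 2 cannot be read as a guide to this step alone.

The expectation for compound 4 in this assay is a step of a 1.6-fold higher number from compound 2 to compound 4 (0.20 log units; within the scatter) from compound 2, small and toward a higher number, possibly not beyond the scatter. Compound 4 is estimated at 8000 nM, with a range from 2500 nM to 25000 nM.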

Compound 4, half-maximal inhibitory concentration: 9800 nM
For compound 4 the middle estimate is 1.2-fold (0.09 log units) below the measured one, and the stated range covers the measured number.
By their numbers in this assay, from the lowest: compounds 2 and 4 (each within the scatter of the next); then compound 3; then compound 1.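

In this assay, the substituent on the saturated chain carbon bound to an amide-type nitrogen now has its first comparison that differs in one place only: 4-methylphenyl in place of 3,5-dimethylphenyl gives a 1.9-fold higher number from compound 2 to compound 4 (0.28 log units; within the scatter). At this place, then, the ring pattern can change from 3,5-dimethylphenyl to 4-methylphenyl with the number staying within the scatter, so this pair gives no sign that the 3,5-dimethyl pattern is needed for the values seen here. Nothing measured on these compounds bears on why the two values sit so close.

Open at this position is how a methoxy group, a chlorine or an amine on this ring would read with the rest of compound 2 held fixed. Within the data shown here, equally open is whether a longer chain in place of the one in compound 2 would move the number beyond the scatter.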